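Swapping Bromo for Chloro in a Cytotoxicity Assay

The source may report more compounds than this note shows. Statements on the series, on what has been measured and on what is new or still open speak of the compounds shown alone.

Compound 1, `COc1ccc(-n2ccnc2SCC(=O)Nc2ccccc2C)cc1`, in an ADME assay on MT4 cells (Homo sapiens) for cytotoxicity, read by MTT assay (a lower number here means that less compound is tolerated, a higher number that more compound is tolerated), gives > 353000 nM; this value is a limit of the assay, not a number.
Compound 2, `O=C(CSc1nccn1-c1ccc(Cl)cc1)Nc1ccccc1Br`, in this assay gives > 300000 nM; this too is a limit.
Compound 3, `COc1ccc(-n2ccnc2SCC(=O)Nc2ccccc2Br)cc1`, in this assay gives > 298000 nM; this also is a limit.

Compound 3 thus stands only at a limit, and the two other values shown are limits as well (the limit of > 298000 nM in this assay, at which 1 of the 3 values shown sits, (the limit of > 300000 nM in this assay, at which 1 of the 3 values shown sits), (the limit of > 353000 nM in this assay, at which 1 of the 3 values shown sits)). The two steps that reach compound 3 cannot be sized: a step that the two limits leave unreadable from compound 1 to compound 3, and a step that the two limits leave unreadable from compound 2 to compound 3.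

The unmeasured compound 4, `COc1ccc(-n2ccnc2SCC(=O)Nc2ccccc2Cl)cc1`, differs from compound 3 by chloro in place of bromo on an aromatic carbon. No measured step bears readably on this change, and no reading of any shown compound sits below its limit, so no step beyond the scatter is expected in this assay in either direction.

The step from compound 3 to compound 4 is expected to be a step that the limit leaves unreadable from compound 3 to compound 4. Compound 4 is therefore estimated at 320000 nM, within a range from 200000 nM to 500000 nM, most likely again reported only as a limit.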

Compound 4, half-maximal cytotoxic concentration: > 334000 nM
Compound 4 gave a limit, no number; the forecaster's own chance of this, stated with the estimate: 85%; at least 1.0-fold (0.01 log units) between middle value and limit.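

Compound 4, like compound 1 and compound 3, stands only at a limit in this assay, so the steps reaching compound 4 from compound 1 and compound 3 cannot be read. The compounds shown leave open whether methyl, bromo or chloro at this place changes cytotoxicity at all.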